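Methylsulfanyl for methoxy on the ethynyl nucleoside

This account rests on a few compounds, and the source may have more. Where it says the series, first, only, none or still open, it means among the compounds named here.

Compound 1 `COc1ncnc2c1c(-c1ccoc1)cn2[C@@H]1O[C@H](CO)[C@@H](O)[C@H]1O` is the reference of the set. In a functional assay on CCRF-CEM cells (Homo sapiens), read by MTT assay, with a stated time of 72 h (a higher number here means a weaker inhibitor, a lower number a stronger inhibitor), compound 1 gives 110 nM. Compound 2 `CSc1ncnc2c1c(-c1ccoc1)cn2[C@@H]1O[C@H](CO)[C@@H](O)[C@H]1O` differs from it by methylsulfanyl in place of methoxy on an aromatic carbon; in this assay compound 2 gives 14200 nM, a step of a 130-fold higher number from compound 1 to compound 2 (2.11 log units; beyond the scatter). Compound 3 `C#Cc1cn([C@@H]2O[C@H](CO)[C@@H](O)[C@H]2O)c2ncnc(OC)c12` carries a different core, the difference being (ethynyl in place of furan-3-yl on an aromatic carbon). For compound 3 only a limit of the assay is known, > 20000 nM, which is the limit described as the limit of > 20000 nM in this assay, at which 1 of the 3 values shown sits. The step of an at least 180-fold higher number from compound 1 to compound 3 (2.25 log units; beyond the scatter) is therefore a lower bound only. Going by the values given here, compound 4 `C#Cc1cn([C@@H]2O[C@H](CO)[C@@H](O)[C@H]2O)c2ncnc(SC)c12` has not been measured; it differs from compound 3 by methylsulfanyl in place of methoxy on an aromatic carbon, the same change as the one made from compound 1 to compound 2, here on the core of compound 3. That change gave a 130-fold higher number from compound 1 to compound 2 (2.11 log units; beyond the scatter) on the core of compound 1, and compound 3 already sits at the limit with > 20000 nM, so a step in the same direction, or at least no lowering of the number, is expected, a step that the limit leaves unreadable from compound 3 to compound 4. Compound 4 is thus expected to give 200000 nM in this assay, most likely reported only as a limit, within a range from 20000 nM to 2000000 nM.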

Compound 4, half-maximal inhibitory concentration: > 20000 nM
Compound 4 ended at the assay's limit (the forecaster's own chance of this, stated with the estimate: 90%); the middle value lies beyond the limit too.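

In this assay compound 4 gives > 20000 nM, which is a limit of the assay and not a number. The step between the methoxy and methylsulfanyl ethynyl nucleosides cannot be read, so this pair says nothing about the size of that change on the second core. Ethynyl in place of furan-3-yl on the methylsulfanyl side gives an at least 1.4-fold higher number from compound 2 to compound 4 (0.14 log units; that floor lies within the scatter), so no lowering of the number appears on either core, but this floor alone does not show a rise beyond the scatter on the methylsulfanyl side, and whether the change carries over at the same size stays undecided: the same change on two cores in this assay, an at least 180-fold higher number (2.25 log units; beyond the scatter) from compound 1 to compound 3 and an at least 1.4-fold higher number (0.14 log units; that floor lies within the scatter) from compound 2 to compound 4; the limit leaves it open whether they differ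

The compounds shown leave open how an amine in place of methoxy would read on either core. They also leave open whether a longer chain in place of ethynyl would bring the number back from the limit.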